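A few compounds are considered here, and "the series" means these few. Any claim that something is new, unique, unknown or untested is made for them only; others in the source may bear on it.

Measured compounds:
- compound 1 `O=C(NCc1ccc(S(=O)(=O)c2cccc(C(F)(F)F)c2)cc1)c1cnc2nccn2c1` — in an assay for inhibition of Nicotinamide phosphoribosyltransferase (Homo sapiens), read by mass spectrometry, with stated times of 15 min and 30 min (a higher number here means a weaker inhibitor, a lower number a stronger inhibitor), compound 1 gives 1 nM
- compound 2 `O=C(NCc1ccc(S(=O)(=O)c2cccc(C(F)(F)F)c2)cc1)c1ccc2nccn2c1` — in this assay compound 2 gives 8 nM

Compound 2 holds the highest number of the two; its nearest neighbour is compound 1, and the step of an 8.0-fold higher number from compound 1 to compound 2 (0.90 log units; beyond the scatter) lies beyond the scatter. Both compounds share the same core, differing only in the group on the carbonyl carbon.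

Compound 3 `O=C(NCc1ccc(S(=O)(=O)c2cccc(C(F)(F)F)c2)cc1)c1cc2ccncc2s1` is not yet measured. Its change from compound 2 is a group of 9 heavy atoms (7 carbon, 1 nitrogen, 1 sulfur; one five-membered aromatic ring with 1 hetero atom, one six-membered aromatic ring with 1 hetero atom) in place of a group of 9 heavy atoms (7 carbon, 2 nitrogen; one five-membered aromatic ring with 2 hetero atoms, one six-membered aromatic ring with 1 hetero atom), on a carbonyl carbon. For the measured compounds named here, the one measured step that bears on this is an 8.0-fold higher number from compound 1 to compound 2 (0.90 log units; beyond the scatter), a modest change arising from an exchange of groups at the same place. That swap moved the number upward; the present swap is a different exchange at the same carbonyl carbon, so the direction is not fixed by the data. In this assay compound 3 is expected to give about 20 nM, with a likely range from 4 nM to 100 nM, meaning an estimated step of a 2.5-fold higher number from compound 2 to compound 3 (0.40 log units; beyond the scatter), probably within the scatter or a little weaker.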

Compound 3, half-maximal inhibitory concentration: 3 nM
Compound 3: middle estimate off by 6.7-fold (0.82 log units), on the high side; measured number outside the range, below it.
By their numbers in this assay, from the lowest: compound 1; then compound 3; then compound 2.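

At the carbonyl carbon, a group with sulfur in its five-membered aromatic ring is accepted in this assay with a 2.7-fold lower number from compound 2 to compound 3 (0.43 log units; beyond the scatter) and still with a 3.0-fold higher number from compound 1 to compound 3 (0.48 log units; beyond the scatter) against the best of the three, so compound 1 remains the strongest inhibitor shown. The first two compounds could suggest that fewer nitrogens in this group give a higher number, but compound 3 goes against that: its group holds the fewest nitrogens, yet compound 2 keeps the highest number. Exchanges at this place can therefore move the number in either direction, and the nitrogen count alone does not order the three compounds.

Nothing available explains this order. Also open, going by these compounds, is how this carbonyl carbon would respond to a single-ring group such as pyridine or to an open chain such as a simple alkyl amine.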